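Dropping the methoxy group: compound 3 to compound 4

A few compounds are considered here, and "the series" means these few. Any claim that something is new, unique, unknown or untested is made for them only; others in the source may bear on it.

Measured so far:
compound 1, `O=S(=O)(NCCCNCc1cccc(Cl)c1)c1cc(C(F)(F)F)cc(C(F)(F)F)c1`, 2600 nM
compound 2, `O=S(=O)(NCCCNCc1ccc(C(F)(F)F)cc1)c1cc(C(F)(F)F)cc(C(F)(F)F)c1`, 1400 nM
compound 3, `COc1ccccc1CNCCCNS(=O)(=O)c1cc(C(F)(F)F)cc(C(F)(F)F)c1`, 2600 nM

In a functional assay on MCF7 cells (Homo sapiens) for inhibition, read by MTT assay, with a stated time of 72 h (on this read-out lower numbers stand for stronger inhibition of growth and higher numbers for weaker inhibition of growth), compound 3 stands level with compound 1, and these two give the highest numbers among the measured compounds; the step of a 1.9-fold higher number from compound 2 to compound 3 (0.27 log units; within the scatter) is the largest gap involving compound 3, and it is within the scatter. Compound 4, `O=S(=O)(NCCCNCc1ccccc1)c1cc(C(F)(F)F)cc(C(F)(F)F)c1`, differs from compound 3 by hydrogen in place of methoxy on an aromatic carbon.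

Among the measured compounds shown here, no measured step removes a substituent from this ring outright; the steps that bear on it are the exchanges of one substituted phenyl for another, no change at the digits printed from compound 1 to compound 3 (within the scatter) and a 1.9-fold higher number from compound 2 to compound 3 (0.27 log units; within the scatter), both within the scatter, as is a 1.9-fold lower number from compound 1 to compound 2 (0.27 log units; within the scatter). Since every change on this ring so far has left the number within the scatter, compound 4 is expected to sit close to compound 3, with the step of no change at the digits printed from compound 3 to compound 4 (within the scatter) expected to be no more than the scatter. Compound 4 is therefore estimated at 2600 nM, in the range 1200 nM to 5500 nM.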

Compound 4, concentration for 50% growth inhibition: 3000 nM
Compound 4: the middle estimate sits 1.2-fold (0.06 log units) below what was measured; measured number inside the range.
By their numbers in this assay, from the lowest: compounds 2, 1, 3 and 4 (each within the scatter of the next, the first and the last beyond it).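

In this assay, compound 4 gives the first read of this ring with no substituent at all: hydrogen in place of methoxy gives a 1.2-fold higher number from compound 3 to compound 4 (0.06 log units; within the scatter), and hydrogen in place of chloro gives a 1.2-fold higher number from compound 1 to compound 4 (0.06 log units; within the scatter), so neither group is shown to differ from hydrogen. Hydrogen in place of trifluoromethyl gives a 2.1-fold higher number from compound 2 to compound 4 (0.33 log units; beyond the scatter), the only step in the series past the scatter, and a modest one, so a small separation appears only for this group. No measurement shown bears on the reason for these steps.

The three substituents sit at different places on the ring, so the effects of group and place remain unseparated. Also open, on these data alone, is whether this narrow spread would hold for a primary amine or a carboxylic acid on the ring, or for a longer chain in the linker.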